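This account rests on a few compounds, and the source may have more. Where it says the series, first, only, none or still open, it means among the compounds named here.

Compound 1, `CCCCNc1nc(N)nc2c1ncn2/C=C1/CC1(CO)CO`: in an ADME assay on BCBL1 cells (Homo sapiens) for cytotoxicity, with a stated time of 7 days (a lower number here means that less compound is tolerated, a higher number that more compound is tolerated), compound 1 gives > 20000 nM, which is a limit of the assay and not a number.
Compound 2, `Nc1nc(OCC(F)(F)F)c2ncn(/C=C3/CC3(CO)CO)c2n1`: in this assay compound 2 gives > 20000 nM, again a limit.
Compound 3, `CSc1nc(N)nc2c1ncn2/C=C1/CC1(CO)CO`: in this assay compound 3 gives > 20000 nM, again a limit.

Compound 1 therefore stands only at a limit, and the two other values shown are limits as well. Every one of the three sits at the limit of > 20000 nM in this assay, at which 3 of the 3 values shown sit, so none of the three compounds shows a tolerated concentration that can be set against another. The step that the two limits leave unreadable from compound 1 to compound 2, the step that the two limits leave unreadable from compound 1 to compound 3 and the step that the two limits leave unreadable from compound 2 to compound 3 are all unreadable for that reason; changing the group on the aromatic carbon from butylamino to 2,2,2-trifluoroethoxy or to methylsulfanyl left every compound at the limit.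

Compound 4 is `CCCCCCOc1nc(N)nc2c1ncn2/C=C1/CC1(CO)CO`. It differs from compound 1 as follows: hexyloxy in place of butylamino on an aromatic carbon. The three measured steps all touch the same aromatic carbon and all stay at the limit, so no direction or size can be read for the change to hexyloxy. The step that the limit leaves unreadable from compound 1 to compound 4 is therefore expected to be none beyond the scatter. For compound 4 in this assay the estimate is 25000 nM, within 8000 nM to 80000 nM, with a limit the most likely outcome.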

Compound 4, half-maximal cytotoxic concentration: > 20000 nM
Compound 4 was reported as a limit; the forecaster's own chance of this, stated with the estimate: 75%; the middle value does not contradict the limit.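

Compound 4, like compound 1, compound 2 and compound 3, gives only a limit in this assay, so none of the new steps to compound 4 can be read: the limit of > 20000 nM in this assay, at which 4 of the 4 values shown sit.

The compounds shown leave open at what concentration any of them harms these cells, and whether the group on the aromatic carbon changes that concentration.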